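This account rests on a few compounds, and the source may have more. Where it says the series, first, only, none or still open, it means among the compounds named here.

In a functional assay on cells (T-cell line, Homo sapiens) for inhibition (on this read-out lower numbers stand for stronger inhibition and higher numbers for weaker inhibition), compound 1 `COc1ccc(CCCN2CCC(COC(c3ccc(Cl)cc3)c3ccc(Cl)cc3)CC2)cc1` gives 1100 nM. Compound 2 `Clc1ccc(CCCN2CCC(COC(c3ccccc3)c3ccccc3)CC2)cc1` gives 500 nM in this assay, the lower of the two numbers recorded so far; the gap between compound 2 and compound 1 lies beyond the usual scatter, so compound 2 stands as the stronger inhibitor of the pair. Compound 3 `C(#Cc1ccccc1)CN1CCC(COC(c2ccccc2)c2ccccc2)CC1` has not been measured yet. It differs from compound 2 in a single place: 2-phenylethynyl in place of 2-(4-chlorophenyl)ethyl on a saturated chain carbon bound to an amine nitrogen in a ring. Among the compounds with values here, no measured pair in this set shows the effect of such a change, so any expectation rests on analogy alone. Given that compound 2 gives 500 nM, the step is expected to be small, most likely toward a somewhat higher number, with a 1.8-fold higher number from compound 2 to compound 3 (0.26 log units; within the scatter) as the estimated shift. Compound 3 is therefore estimated at 900 nM in this assay, within a range of 300 nM to 3000 nM.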

Compound 3, half-maximal inhibitory concentration: > 20000 nM
Compound 3: a limit, no number; the forecaster's own chance of this, stated with the estimate: 5%; middle value at least 22-fold (1.34 log units) away from the limit.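

In this assay compound 3 gives a limit of the assay and not a number: the limit of > 20000 nM in this assay, at which 1 of the 3 values shown sits. Even so, the step can be read as an at least 40-fold higher number from compound 2 to compound 3 (1.60 log units; beyond the scatter), the first reading of a single change in this set. It shows that inhibition in this assay is far from indifferent to what sits on a saturated chain carbon bound to an amine nitrogen in a ring: the change from 3-(4-chlorophenyl)propyl to 3-phenylprop-2-yn-1-yl takes the read-out from a measurable number to that limit.

This one change brings in the triple bond and removes the chlorine together, and the compounds shown do not separate the two. A plain 3-phenylpropyl group or a 3-(4-chlorophenyl)prop-2-yn-1-yl group in the same place would show which of them goes with the large step.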